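The source may hold more compounds than are shown below. What is called first, only, known or untested is meant among the compounds shown, and "the series" means these compounds.

In a functional assay on MIA PaCa-2 cells (Homo sapiens) for antiproliferative activity, read by MTT assay, with a stated time of 72 h (on this read-out higher numbers stand for weaker inhibition and lower numbers for stronger inhibition), compound 1 `COc1nc(CC(O)(COCc2ccccc2)COCc2ccccc2)c(C)c(OC)n1` gives 6100 nM. Compound 2 `O=c1cc(CC(O)(COCc2ccccc2)COCc2ccccc2)[nH]c(=O)[nH]1` gives > 100000 nM, and this value is a limit of the assay, not a number. Compound 2 therefore has no exact place on the scale.

Compound 3 `C[Si](C)(C)CCOCn1c(CC(O)(COCc2ccccc2)COCc2ccccc2)cc(=O)[nH]c1=O` differs from compound 2 in one place: a group of 8 heavy atoms (6 carbon, 1 oxygen, 1 silicon; no ring) in place of a hydrogen atom, on an aromatic nitrogen. A group with no common name and no ring takes the place of a hydrogen atom on an aromatic nitrogen, while the rest of the structure stays the same. For the measured compounds named here, no step between measured compounds shows what such a change does, so any expectation rests on little. Going by the values given here, the value of compound 1, 6100 nM, shows only that a compound carrying the same two benzyl-bearing arms can give a number in this assay. On that basis, a shift toward stronger inhibition, beyond the usual scatter, is expected, though compound 3 may yet stay at the limit. The expected change is an at least 5.0-fold lower number from compound 2 to compound 3 (0.69 log units; beyond the scatter), a figure that counts from a limit. Compound 3 is estimated at 20000 nM, with an expected range from 5000 nM to 100000 nM.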

Compound 3, half-maximal inhibitory concentration: > 100000 nM
Compound 3 was reported as a limit; the forecaster's own chance of this, stated with the estimate: 35%; at least 5.0-fold (0.69 log units) between middle value and limit.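

Compound 3 gives > 100000 nM, which is a limit of the assay and not a number. For the compounds shown here, compound 2 is also reported only as a limit, so no step from compound 2 to compound 3 can be read: the limit of > 100000 nM in this assay, at which 2 of the 3 values shown sit. The compounds shown leave open whether the group on the aromatic nitrogen of compound 3 changes inhibition at all.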